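Second Chloro on the Fused Core of Compound 2

A few compounds are considered here, and "the series" means these few. Any claim that something is new, unique, unknown or untested is made for them only; others in the source may bear on it.

Compound 1 `ClCc1ccccc1Cn1cnc2c(Cl)nc(Cl)nc21`: 720 nM
Compound 2 `ClCc1ccccc1Cn1cnc2ncnc(Cl)c21`: 2950 nM

In a functional assay on SN12C cells (Homo sapiens) for cytotoxicity, read by sulforhodamine B assay, with a stated time of 48 h (a lower number here means a stronger inhibitor of growth, a higher number a weaker inhibitor of growth), compound 2 holds the higher of the two numbers, with compound 1 giving the lower one, a gap beyond the scatter. Compound 3 `ClCc1ccccc1Cn1cnc2nc(Cl)nc(Cl)c21` arises from compound 2 by chloro in place of hydrogen on an aromatic carbon, on a carbon between two ring nitrogen atoms. Within the data shown here, no measured pair isolates this change, so any expectation rests on compound 1 alone, which is the only compound giving a low number with two chloro groups present. A step downward is expected, estimated as a 2.3-fold lower number from compound 2 to compound 3 (0.36 log units; beyond the scatter). Compound 3 is expected near 1300 nM, within 450 nM to 3800 nM.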

Compound 3, concentration for 50% growth inhibition: 1170 nM
For compound 3 the middle estimate is 1.1-fold (0.05 log units) above the measured one; the measured number falls inside the stated range.
By their numbers in this assay, from the lowest: compounds 1 and 3 (each within the scatter of the next); then compound 2.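

Read by this assay the swap of hydrogen for chloro on the aromatic carbon between two ring nitrogen atoms gives a 2.5-fold lower number from compound 2 to compound 3 (0.40 log units; beyond the scatter) and is the first step shown that isolates a single change. The position therefore accepts a chloro group, and the hydrogen there is not required for this level of growth inhibition. Nothing given here accounts for the step. On these data alone, whether an amine or a methoxy group on this same carbon would lower the number further, match chloro or raise the number remains open.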